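Swapping methyl for methylsulfonyl on the pyrazole nitrogen

The compounds below may be only part of what the source reports. "The series", "measured", "known", "first", "only" and "open" are said of these compounds alone.

Measured compounds:
compound 1 `CNC(=O)N1CCCc2ccc(NC(=O)c3cccc(-c4ccccc4)c3)cc21`: 2.83%
compound 2 `CNC(=O)N1CCCc2ccc(NC(=O)c3ccc(-c4ccn(C)n4)cc3)cc21`: 72.2%
compound 3 `CNC(=O)N1CCCc2ccc(NC(=O)c3cccc(-c4cn[nH]c4)c3)cc21`: 27.9%

All three share one core and differ only in the aromatic group attached to the amide. In a functional assay on MV4-11 cells (Homo sapiens) for antiproliferative activity, with a stated time of 6 days, tested at 1.56 uM (a lower number here means a weaker effect, a higher number a stronger effect of the compound at the concentration tested), compound 2 gives the highest of the three numbers, well beyond the scatter above compound 3 and further still above compound 1. Within the data shown here, the only single-point step among the measured compounds is a number 25.1 percentage points higher from compound 1 to compound 3 (beyond the scatter), which changes the ring itself, not a group on it.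

Compound 4 `CNC(=O)N1CCCc2ccc(NC(=O)c3ccc(-c4ccn(S(C)(=O)=O)n4)cc3)cc21` is derived from compound 2 by one change: methylsulfonyl in place of methyl on an aromatic nitrogen. Among the measured compounds shown here, no measured step concerns a group on the aromatic nitrogen, so the data give no direct guide to its size or direction. Compound 2 is the starting point, so its value is the anchor, with a wide band to either side. The expected step is a number 22.2 percentage points lower from compound 2 to compound 4 (beyond the scatter). For compound 4 in this assay the estimate is 50%, within a range from 15% to 80%.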

Compound 4, a percentage reported as inhibition, at one concentration (the size of the read-out at that concentration, not a potency): 8.81%
Beside the measured number, compound 4's estimate is 41.2 percentage points above it; measured number below the stated range.
By their numbers in this assay, from the lowest: compounds 1 and 4 (each within the scatter of the next); then compound 3; then compound 2.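

Putting methylsulfonyl in place of methyl on this aromatic nitrogen gives a number 63.4 percentage points lower from compound 2 to compound 4 (beyond the scatter) in this assay. The earlier step swapped one ring for another, whereas this one keeps the 1H-pyrazol-3-yl ring and alters only the group on its nitrogen, showing that this single position can decide much of the read-out. Methylsulfonyl brings 4 heavy atoms and 2 hydrogen-bond acceptors where methyl has 1 heavy atom and 0 acceptors, but no measurement here links either difference to the loss, so its cause remains unknown.

On these data alone, it remains open whether any group larger than methyl on this nitrogen lowers the number or whether the drop is specific to methylsulfonyl. An ethyl or an acetyl group at the same position would help separate these two readings.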